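The source may hold more compounds than are shown below. What is called first, only, known or untested is meant among the compounds shown, and "the series" means these compounds.

Compounds measured in a physicochemical assay for acid dissociation:

Compound 1 `c1ccc(Oc2ccc3c(NCCCNCc4ccco4)ccnc3c2)cc1` gives 9.28.
Compound 2 `Fc1ccc(Oc2ccc3c(NCCCNCc4ccco4)ccnc3c2)cc1` gives 9.28.
Compound 3 `COc1ccc(F)cc1CNCCCNc1ccnc2cc(CCc3ccccc3)ccc12` gives 9.47.

Compound 3 carries the highest of the three numbers, but its distance from compound 1 and from compound 2 lies within the scatter, so the three values cannot be ordered. Compound 4 `c1ccc(CCc2ccc3c(NCCCNCc4ccco4)ccnc3c2)cc1` is not yet measured. It differs from compound 3 by furan-2-yl in place of 5-fluoro-2-methoxyphenyl on a saturated chain carbon bound to an amine nitrogen.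

Within the data shown here, the only measured step, no change at the digits printed from compound 1 to compound 2 (within the scatter), touches a different part of the molecule and is small. Compound 1 and compound 2 already carry the (furan-2-yl)methyl group, and their values sit within the scatter of compound 3. Compound 4 is therefore expected to move only a number 0.17 log units lower from compound 3 to compound 4 (within the scatter), with no direction beyond the scatter. The estimate for compound 4 is 9.3, between 9 and 9.6.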

Compound 4, acid dissociation constant: 9.47
Compound 4: middle estimate off by 0.17 log units, on the low side; the measured number falls inside the stated range.
By their numbers in this assay, from the lowest: compounds 1, 2, 3 and 4 (each within the scatter of the next).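

In this assay, furan-2-yl in place of 5-fluoro-2-methoxyphenyl on a saturated chain carbon bound to an amine nitrogen gives no change at the digits printed from compound 3 to compound 4 (within the scatter) and shows that this larger exchange at the chain end leaves the reading within the scatter. On the aromatic carbon, phenethyl in place of phenoxy gives a number 0.19 log units higher from compound 1 to compound 4 (within the scatter) and phenethyl in place of 4-fluorophenoxy gives a number 0.19 log units higher from compound 2 to compound 4 (within the scatter), so neither exchange there moves the reading beyond the scatter either. No evidence bearing on these results is available. Going by these compounds, whether a carboxylic acid or a second amine at the chain end, or a longer chain, would move the reading beyond the scatter remains open.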